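The source may hold more compounds than are shown below. What is called first, only, known or untested is meant among the compounds shown, and "the series" means these compounds.

The set holds three measured compounds and one awaiting measurement. Compound 1 `N/C(=N\NC(=S)N1CCSCC1)c1ccccn1` gives 8800 nM in a functional assay on MCF7 cells (Homo sapiens) for cytotoxicity, read by MTT assay, with a stated time of 72 h; on this read-out higher numbers stand for weaker inhibition and lower numbers for stronger inhibition. Compound 2 `Cc1cccc(/C(N)=N/NC(=S)N2CCCCC2)n1` gives 74000 nM in this assay, and compound 3 `N/C(=N\NC(=S)N1CCOCC1)c1ccc(F)cn1` gives 22100 nM. Among these three numbers compound 3 holds the second highest: its nearest neighbour is compound 1, whose number is lower by a margin beyond the usual scatter, while compound 2 lies furthest away, higher by a margin that is also beyond the scatter. Compound 4 `N/C(=N\NC(=S)N1CCOCC1)c1ccccn1` has not yet been measured. It differs from compound 3 in a single place: hydrogen in place of fluoro on an aromatic carbon. Among the measured compounds shown here, no measured pair in this set shows that same change, so nothing here fixes its size directly. The expectation is a small step, a 1.5-fold lower number from compound 3 to compound 4 (0.17 log units; within the scatter), toward a lower number and within the scatter. Compound 4 is accordingly estimated at 15000 nM, with a plausible range running from 5000 nM to 45000 nM.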

Compound 4, half-maximal inhibitory concentration: 4700 nM
For compound 4 the middle estimate is 3.2-fold (0.50 log units) above the measured one, and the stated range ends above it.
By their numbers in this assay, from the lowest: compounds 4 and 1 (each within the scatter of the next); then compound 3; then compound 2.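

In this assay, among the compounds shown here, the aromatic carbon two atoms from the ring nitrogen and para to a large group proves sensitive to this change: hydrogen in place of fluoro gives a 4.7-fold lower number from compound 3 to compound 4 (0.67 log units; beyond the scatter) and so shows a real difference at a position no earlier pair had tested. With hydrogen at that place, morpholin-4-yl in place of thiomorpholin-4-yl on the thiocarbonyl carbon gives a 1.9-fold lower number from compound 1 to compound 4 (0.27 log units; within the scatter) and so separates the two compounds by no more than the usual scatter. Nothing available accounts for the step from fluoro to hydrogen.

Still open, going by these compounds, is whether chloro, methoxy or an amine on the same aromatic carbon would match fluoro or hydrogen in this assay as a result. Also open, on these data alone, is whether the step from fluoro to hydrogen keeps its size with thiomorpholin-4-yl on the thiocarbonyl carbon.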